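This account rests on a few compounds, and the source may have more. Where it says the series, first, only, none or still open, it means among the compounds named here.

Compound 1 `COC(=O)CNc1cc(NS(=O)(=O)/C=C/c2c(OC)cc(OC)cc2OC)ccc1OC` gives 350 nM
Compound 2 `COC(=O)C(Nc1cc(NS(=O)(=O)/C=C/c2c(OC)cc(OC)cc2OC)ccc1OC)c1ccccc1` gives 2500 nM

In a functional assay on K562 cells (Homo sapiens) for cytotoxicity, read by trypan blue exclusion, with a stated time of 96 h (a higher number here means a weaker inhibitor, a lower number a stronger inhibitor), compound 2 stands at 2500 nM as the higher of the two numbers, which makes it the weaker inhibitor of the pair. Compound 3 `COC(=O)C(Nc1cc(NS(=O)(=O)/C=C/c2c(OC)cc(OC)cc2OC)ccc1OC)c1ccc(Cl)cc1` differs from compound 2 in one place (chloro in place of hydrogen on an aromatic carbon). A chloro takes the place of a hydrogen on an aromatic carbon, so phenyl becomes 4-chlorophenyl.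

Within the data shown here, the one measured step that bears on this is the arrival of the phenyl itself (a 7.1-fold higher number from compound 1 to compound 2 (0.85 log units; beyond the scatter)), a modest step beyond the scatter. It shows that a change on this side of the molecule can move the number. However, that step added a whole ring, and no measured pair shows what a group on that ring does. Among the measured compounds shown here, with so small an addition and no direct precedent, no step beyond the scatter is expected in this assay and neither direction is favoured. The estimated step is accordingly slight (no change at the digits printed from compound 2 to compound 3 (within the scatter)). Compound 3 is expected near 2500 nM with 800 nM and 7000 nM as the estimated lower and upper ends.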

Compound 3, half-maximal inhibitory concentration: 2500 nM
Estimate against measurement, compound 3: no gap at the digits printed; low and high end bracket the measured number.
By their numbers in this assay, from the lowest: compound 1; then compounds 2 and 3 (each within the scatter of the next).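

In this assay there is no change at the digits printed from compound 2 to compound 3 (within the scatter), so a chloro on the added ring, para to a large group, makes no readable difference to the number. The higher number that came with the ring also persists with the chloro in place: there is a 7.1-fold higher number from compound 1 to compound 3 (0.85 log units; beyond the scatter), the same size as a 7.1-fold higher number from compound 1 to compound 2 (0.85 log units; beyond the scatter), so this single chloro does not win back what separates the ring-bearing compounds from compound 1. Nothing available here explains why the chloro leaves the reading as it was.

The compounds shown carry only one kind of group at one place on this ring, so a single chloro cannot speak for the ring as a whole, and an amine or a carboxylic acid at that spot might read differently. From the compounds shown here alone, it also remains open whether the higher number belongs to the phenyl ring itself or to any branch on that chain carbon, a question that a small methyl at the same carbon could help to settle.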